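The compounds below may be only part of what the source reports. "The series", "measured", "known", "first", "only" and "open" are said of these compounds alone.

Measured compounds:
Compound 1, `Brc1cn2ccnc2c(-c2ccc3ncn(C4CCCCC4)c3c2)n1`: 49.7%
Compound 2, `c1ccc2c(-c3cn4ccnc4c(-c4ccc5ncn(C6CCCCC6)c5c4)n3)cccc2c1`: 41.3%
Compound 3, `CC(=O)c1ccc(-c2cn3ccnc3c(-c3ccc4ncn(C5CCCCC5)c4c3)n2)cc1`: 54.4%

In a functional assay on T47D cells (Homo sapiens) for inhibition, read by sulforhodamine B assay, with a stated time of 48 h, tested at 10 uM (a higher number here means more inhibition at the concentration tested (going by the name of the read-out), a lower number less inhibition), compound 3 gives the highest of the three numbers, though it stands within the scatter of compound 1 and clearly apart from compound 2 only by a number 13.1 percentage points higher from compound 2 to compound 3 (beyond the scatter). Compound 4, `Brc1ccc(-c2cn3ccnc3c(-c3ccc4ncn(C5CCCCC5)c4c3)n2)cc1`, differs from compound 3 in one place: bromo in place of acetyl on an aromatic carbon. For the measured compounds named here, no measured step swaps these two groups on the phenyl ring itself. The nearest comparison is the change from a bare bromo to the 4-acetylphenyl group, a number 4.7 percentage points higher from compound 1 to compound 3 (within the scatter), which lay within the scatter. On that basis a small shift in this assay is expected, most likely slightly downward, and for compound 4 the expected step is a number 8.4 percentage points lower from compound 3 to compound 4 (within the scatter). Compound 4 is therefore estimated at 46%, between 32% and 58%.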

Compound 4, a percentage reported as inhibition, at one concentration (the size of the read-out at that concentration, not a potency): 55%
Beside the measured number, compound 4's estimate is 9 percentage points below it, within the range that was stated.
By their numbers in this assay, from the lowest: compounds 2, 1, 3 and 4 (each within the scatter of the next, the first and the last beyond it).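

In this assay the swap gives a number 0.6 percentage points higher from compound 3 to compound 4 (within the scatter) and so, on this ring, bromo and acetyl cannot be told apart, although only acetyl carries a hydrogen-bond acceptor. Against the other two compounds, a number 13.7 percentage points higher from compound 2 to compound 4 (beyond the scatter) goes beyond the scatter, while a number 5.3 percentage points higher from compound 1 to compound 4 (within the scatter) stays within it, so adding the phenyl ring to the bromo shows no clear change. No measured evidence accounts for these numbers.

On these data alone, whether an amine or a carboxylic acid in this same place would also leave the number unchanged stays open.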